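The source may report more compounds than this note shows. Statements on the series, on what has been measured and on what is new or still open speak of the compounds shown alone.

Measured so far in a physicochemical assay for lipophilicity, in phosphate buffer, measured as octanol-water partition, at pH 11.5; a lower number here means a more polar compound, a higher number a more lipophilic compound
- compound 1 `CCCCCCCCNC(=N)NC(=N)Nc1ccc(C)cc1` gives 4.93
- compound 2 `CCCCCCCCOC(=N)NC(=N)Nc1ccc(Cl)cc1` gives 5.32

Compound 1 stands lowest of the two at 4.93 in this assay on these numbers, and compound 2 lies higher, beyond the scatter. Next is compound 3 `CCCCCCCCNC(=N)NC(=N)Nc1ccc(OC)cc1`, which differs from compound 1 by methoxy in place of methyl on an aromatic carbon, para to a large group. Within the data shown here, no measured pair shows this change alone, so the expectation rests on the structural change itself. A downward step beyond the scatter is expected, estimated as a number 0.43 log units lower from compound 1 to compound 3 (beyond the scatter) in this assay for now. Compound 3 is estimated at 4.5 with an expected range of 4.15 to 4.85 in this assay as well.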

Compound 3, partition coefficient: 4.41
Beside the measured number, compound 3's estimate is 0.09 log units above it; measured number inside the range.
By their numbers in this assay, from the lowest: compound 3; then compound 1; then compound 2.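

In this assay, among these compounds, methoxy in place of methyl on an aromatic carbon, para to a large group, gives a number 0.52 log units lower from compound 1 to compound 3 (beyond the scatter) as the first single-place step, so this position now has a measured sensitivity to substitution. The change adds one oxygen, counted as a hydrogen-bond acceptor, and leaves the rest of the core of compound 1 untouched. No measurement in hand accounts for the size of this step. One step cannot show whether ethoxy, an amine or a carboxylic acid at this position would follow the same direction. From the compounds shown here alone, the effect of the same methoxy change alongside a longer chain also remains open.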